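Furan-2-yl replacing 2,4-difluorophenyl in a small series

The source may report more compounds than this note shows. Statements on the series, on what has been measured and on what is new or still open speak of the compounds shown alone.

Measured so far in a functional assay on SMMC-7721 cells (Homo sapiens) for cytotoxicity, read by MTT assay, with a stated time of 72 h (on this read-out lower numbers stand for stronger inhibition and higher numbers for weaker inhibition), on this series:
- compound 1 `O=C1C(=Cc2cccc(Cl)c2)C(=O)N(c2ccc(Cl)cc2)N1c1ccc(Cl)cc1` gives 20200 nM
- compound 2 `O=C1C(=Cc2ccc(F)cc2F)C(=O)N(c2ccc(Cl)cc2)N1c1ccc(Cl)cc1` gives 35800 nM

Compound 2 stands level with compound 1 within the scatter, so the two values cannot be told apart. Next comes compound 3 `O=C1C(=Cc2ccco2)C(=O)N(c2ccc(Cl)cc2)N1c1ccc(Cl)cc1` with furan-2-yl in place of 2,4-difluorophenyl on a double-bonded chain carbon bound to a double-bonded ring carbon. Among the compounds with values here, the only measured step at this place (a 1.8-fold higher number from compound 1 to compound 2 (0.25 log units; within the scatter)) stayed within the scatter, so no step beyond the scatter is expected in this assay, and no direction is favoured. Within the data shown here, that step joined two phenyl groups, and no measured compound carries a five-membered aromatic ring, so the range stays wide. The estimated step (a 1.3-fold lower number from compound 2 to compound 3 (0.11 log units; within the scatter)) is small. For compound 3 the estimated value is 28000 nM with an expected range from 11000 nM to 70000 nM as a working figure.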

Compound 3, half-maximal inhibitory concentration: 19500 nM
For compound 3 the middle estimate is 1.4-fold (0.16 log units) above the measured one; the range from low to high includes it.
By their numbers in this assay, from the lowest: compounds 3, 1 and 2 (each within the scatter of the next).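

In this assay, furan-2-yl on a double-bonded chain carbon bound to a double-bonded ring carbon gives a 1.8-fold lower number from compound 2 to compound 3 (0.26 log units; within the scatter) and a 1.0-fold lower number from compound 1 to compound 3 (0.02 log units; within the scatter) with both steps within the scatter. This place therefore now holds a five-membered aromatic ring with a hetero atom and a hydrogen-bond acceptor, as well as the two phenyl groups, and compound 1, compound 2 and compound 3 stand level. No data at hand bear on the reason for this result.

Going by these compounds, whether an amine or a carboxylic acid at this place would give a step beyond the scatter remains open. Also open, on these data alone, is what a change to the shared core would do, as it stays the same in all three compounds.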